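From a chlorophenyl to a naphthyl arm

This account rests on a few compounds, and the source may have more. Where it says the series, first, only, none or still open, it means among the compounds named here.

For the measured compounds named here, compound 2 `Cc1cc(S(=O)(=O)/N=C(\N)N/N=C/C#Cc2ccccc2)c(SCc2ccc(Cl)cc2)cc1Cl` gives 5000 nM in an ADME assay on HaCaT cells (Homo sapiens) for cytotoxicity, read by MTT assay, with a stated time of 72 h (a lower number here means a stronger inhibitor, a higher number a weaker inhibitor), the lower of the two numbers measured so far; compound 1 `Cc1cc(S(=O)(=O)/N=C(\N)N/N=C/C#Cc2ccccc2)c(SCc2ccccc2)cc1Cl` gives 145000 nM. Going by the values given here, the one measured step, a 29-fold lower number from compound 1 to compound 2 (1.46 log units; beyond the scatter), shows that a change on the ring attached to the saturated chain carbon bound to a sulfur can shift the number strongly. Compound 3 `Cc1cc(S(=O)(=O)/N=C(\N)N/N=C/C#Cc2ccccc2)c(SCc2cccc3ccccc23)cc1Cl` differs from compound 2 by naphthalen-1-yl in place of 4-chlorophenyl on a saturated chain carbon bound to a sulfur. Among the compounds with values here, only that single step bears on this, and it concerned a different change, so the direction here is uncertain. Compound 3 is expected to give 8000 nM, within 2000 nM to 40000 nM, a step of a 1.6-fold higher number from compound 2 to compound 3 (0.20 log units; within the scatter) that may or may not exceed the scatter.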

Compound 3, half-maximal inhibitory concentration: 5000 nM
Estimate against measurement, compound 3: 1.6-fold (0.20 log units) above, and the stated range covers the measured number.
By their numbers in this assay, from the lowest: compounds 2 and 3 (each within the scatter of the next); then compound 1.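

In this assay the two-ring naphthalen-1-yl arm and the 4-chlorophenyl arm cannot be told apart, with no change at the digits printed from compound 2 to compound 3 (within the scatter) on this swap. Naphthalen-1-yl in place of phenyl gives a 29-fold lower number from compound 1 to compound 3 (1.46 log units; beyond the scatter) and thus matches the step seen with chlorine, so at this position a group holding no chlorine can also reach the lower number. No measured evidence here explains this result.

Still open, as far as these compounds go, is whether other groups on this saturated chain carbon, such as naphthalen-2-yl, a pyridine ring or a phenyl ring bearing a carboxylic acid, would give the same number.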